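Cyclohexyl to cyclooctyl on the amide nitrogen: cytotoxicity

A few compounds are considered here, and "the series" means these few. Any claim that something is new, unique, unknown or untested is made for them only; others in the source may bear on it.

The series is built on compound 1, `OC[C@@H]1[C@@H](O)[C@H](O)[C@@H](O)CN1CCCCCCN(C1CCCCC1)C1CCCCC1`, and compound 2, `CC(C)(C)C(=O)N(CCCCCCN1C[C@H](O)[C@@H](O)[C@H](O)[C@H]1CO)C1CCCCC1`. In an ADME assay on MDBK cells (Bos taurus) for cytotoxicity, read by MTT assay (a lower number here means that less compound is tolerated, a higher number that more compound is tolerated), compound 1 reaches only a limit, > 500000 nM. In this assay compound 2 likewise reaches only a limit, > 500000 nM. Within the data shown here, the one measured step, a step that the two limits leave unreadable from compound 1 to compound 2, is therefore not readable in size, since both values sit at the limit of > 500000 nM in this assay, at which 2 of the 2 values shown sit. Compound 2 thus stands at the edge of what this assay can report, with no number of its own.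

Compound 3, `CC(C)(C)C(=O)N(CCCCCCN1C[C@H](O)[C@@H](O)[C@H](O)[C@H]1CO)C1CCCCCCC1`, is the next member; it differs from compound 2 only by cyclooctyl in place of cyclohexyl on an amide-type nitrogen. Among the measured compounds shown here, no measured step bears directly on this change, and the only step in hand is unreadable. The expectation for this assay is therefore that compound 3 will again tolerate more than the assay can resolve, so that the step that the limit leaves unreadable from compound 2 to compound 3 is estimated to stay within the scatter. For compound 3 in this assay the estimate is 600000 nM, with a range from 250000 nM to 2000000 nM, most likely reported again as a limit.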

Compound 3, half-maximal cytotoxic concentration: 270000 nM
Compound 3: the middle estimate sits 2.2-fold (0.35 log units) above what was measured, within the range that was stated.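

Among these compounds, compound 3 is the first member of the series with a number of its own in this assay: compound 3 gives 270000 nM, a measured value rather than a limit. Cyclooctyl in place of cyclohexyl on an amide-type nitrogen gives an at least 1.8-fold lower number from compound 2 to compound 3 (0.26 log units; that floor lies within the scatter), so this change can bring the read-out inside the range of the assay, although the floor of the step alone does not clear the usual scatter and the true size of the step remains unknown. The step between the two earlier compounds cannot be read, and a reading of this position was possible only once compound 3 came off the shared ceiling: the limit of > 500000 nM in this assay, at which 2 of the 3 values shown sit.

Two ring sizes on this nitrogen, one of them known only as a limit, cannot establish a trend with ring size, and the data give no cause for the step. From the compounds shown here alone, it remains open where the read-out would fall with a cycloheptyl ring or a phenyl ring on the same amide-type nitrogen, and whether cyclooctyl would give a comparable value if the tert-butyl carbonyl were replaced by an acetyl group.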